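The source may report more compounds than this note shows. Statements on the series, on what has been measured and on what is new or still open speak of the compounds shown alone.

Values measured in a functional assay on K562 cells (Homo sapiens) for antiproliferative activity, read by MTT assay, with a stated time of 48 h (a lower number here means a stronger inhibitor of growth, a higher number a weaker inhibitor of growth), are as follows:
- Compound 1 `COc1ccc(N(C)c2ncnc3c2ncn3Cc2cc(OC)cc(OC)c2)cc1` gives 42000 nM
- Compound 2 `COc1ccc(Cn2cnc3c(N(C)c4ccc(OC)cc4)nc(Cl)nc32)cc1` gives > 100000 nM which is a limit of the assay and not a number
- Compound 3 `COc1ccc(N(C)c2nc(Cl)nc3c2ncn3Cc2cc(OC)cc(OC)c2)cc1` gives 42000 nM

Compound 3 stands level with compound 1 at the digits shown, and the only other result is the limit of compound 2.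

Compound 4 `COc1cc(Cn2cnc3c(Cl)nc(Cl)nc32)cc(OC)c1` differs from compound 3 at one place (chloro in place of (4-methoxyphenyl)(methyl)amino on an aromatic carbon) with chloro in place of (4-methoxyphenyl)(methyl)amino on an aromatic carbon.

Within the data shown here, two measured steps bear on this comparison. Chloro in place of hydrogen on an aromatic carbon gave no change at the digits printed from compound 1 to compound 3 (within the scatter) and 3,5-dimethoxyphenyl in place of 4-methoxyphenyl on a saturated chain carbon bound to an aromatic nitrogen gave an at least 2.3-fold lower number from compound 2 to compound 3 (0.37 log units; beyond the scatter) in the same test. Compound 4 keeps both of these features, but neither step touches the group that now leaves, and every measured compound carries that group. The guidance is therefore weak, and the best expectation in this assay is no step beyond the scatter, with either direction possible. The estimated change is a 1.2-fold lower number from compound 3 to compound 4 (0.08 log units; within the scatter) as a rough expectation. For compound 4 the estimated value is 35000 nM with an expected range from 8000 nM to 100000 nM as its limits.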

Compound 4, concentration for 50% growth inhibition: 4600 nM
Compound 4: the middle estimate sits 7.6-fold (0.88 log units) above what was measured; measured number outside the range, below it.
By their numbers in this assay, from the lowest: compound 4; then compounds 1 and 3 (each within the scatter of the next). At a limit, above all of these: compound 2.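

Every earlier compound carries the (4-methoxyphenyl)(methyl)amino group, so the earlier results say nothing about this position; in this assay, replacing that group with chloro gives a 9.1-fold lower number from compound 3 to compound 4 (0.96 log units; beyond the scatter). The group and its six-membered aromatic ring are therefore not required for this level of growth inhibition, and a single chlorine atom in its place gives the lower number. This position also responds more strongly than the carbon where chloro replaced hydrogen, which gave no change at the digits printed from compound 1 to compound 3 (within the scatter).

Nothing measured here bears on why the number falls at this position. As far as these compounds go, it remains open whether chloro itself matters or whether losing the larger group is enough, a question that a hydrogen, a methoxy group or a small amine such as dimethylamino at this position could help to settle.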